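Adding a methoxy group to the nitro series of styryl sulfones

A few compounds are considered here, and "the series" means these few. Any claim that something is new, unique, unknown or untested is made for them only; others in the source may bear on it.

Compound 1 `COc1ccc(CS(=O)(=O)/C=C/c2ccccc2OC)cc1N`, measured in a functional assay on K562 cells (Homo sapiens) for cytotoxicity, read by trypan blue exclusion, with a stated time of 96 h (a higher number here means a weaker inhibitor, a lower number a stronger inhibitor), gives 7500 nM.
Compound 2 `COc1ccc(CS(=O)(=O)/C=C/c2c(OC)cccc2OC)c([N+](=O)[O-])c1` gives 50000 nM in this assay.
Compound 3 `COc1ccc(/C=C/S(=O)(=O)Cc2ccc(OC)c(N)c2)c(OC)c1` gives 500 nM in this assay.

Compound 3 differs from compound 1 in one place: methoxy in place of hydrogen on an aromatic carbon. This single change brought a 15-fold lower number from compound 1 to compound 3 (1.18 log units; beyond the scatter), a large step toward stronger inhibition of the cells. Compound 2 stands at the weak end of the three, and its core is not the same as the core of compound 1; the difference between the two cores is not broken down here.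

Compound 4 `COc1cc(OC)c(/C=C/S(=O)(=O)Cc2ccc(OC)cc2[N+](=O)[O-])c(OC)c1` has not yet been measured. It differs from compound 2 by methoxy in place of hydrogen on an aromatic carbon. Within the data shown here, this is the same kind of change as the one from compound 1 to compound 3, though the surroundings are not identical: in compound 4 the new group sits meta to two methoxy groups, whereas in compound 3 it sits meta to a methoxy group. If the change behaves as before, compound 4 is expected to give a clearly lower number than compound 2 in this assay, a step estimated as a 6.3-fold lower number from compound 2 to compound 4 (0.80 log units; beyond the scatter), because the earlier change gave a 15-fold lower number from compound 1 to compound 3 (1.18 log units; beyond the scatter). Among the measured compounds shown here, only one example of this change is known, and the two cores differ, so the size is uncertain. Compound 4 is expected to give about 8000 nM, within 2500 nM to 30000 nM.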

Compound 4, half-maximal inhibitory concentration: 20000 nM
Estimate against measurement, compound 4: 2.5-fold (0.40 log units) below; the measured number falls inside the stated range.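

Placing methoxy where a hydrogen stood on an aromatic carbon again lowered the number in this assay, giving a 2.5-fold lower number from compound 2 to compound 4 (0.40 log units; beyond the scatter), so the direction of the change held on the core of compound 2 as it did on the core of compound 1. The size did not hold, and the gap between the two steps is larger than repeated measurements would explain: the same change on two cores in this assay, a 15-fold lower number (1.18 log units; beyond the scatter) from compound 1 to compound 3 and a 2.5-fold lower number (0.40 log units; beyond the scatter) from compound 2 to compound 4, 6.0-fold (0.78 log units) apart, beyond the scatter of two such steps These two pairs show that the same small change can give steps of clearly different size in this series, but they do not show which part of the difference between the cores goes with the smaller step, nor which size a third core would follow.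

Methoxy is the only group shown entering at this kind of place, so it remains open whether an ethoxy group, a hydroxyl group or a fluorine atom would lower the number in the same way. Among these compounds, also open is whether the nitro and amino groups themselves go with the difference in step size, as no pair here changes one into the other with all else equal.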